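Aniline ring variation on a shared quinazoline-amide series

The compounds below may be only part of what the source reports. "The series", "measured", "known", "first", "only" and "open" are said of these compounds alone.

Three compounds share one core and differ only in the ring on the aromatic nitrogen. Compound 1 `C#Cc1cccc(Nc2ncnc3cc(OC)c(OCCCCC(=O)Nc4ccc(S(N)(=O)=O)cc4)cc23)c1` gives 18800 nM in a functional assay on NCI-H1975 cells (Homo sapiens) for antiproliferative activity, read by MTT assay, with a stated time of 72 h; on this read-out lower numbers stand for stronger inhibition and higher numbers for weaker inhibition. Compound 2 `COc1cc2ncnc(Nc3cccc(C)c3)c2cc1OCCCCC(=O)Nc1ccc(S(N)(=O)=O)cc1` gives 32100 nM in this assay, and compound 3 `COc1cc2ncnc(Nc3cc(F)c(F)c(F)c3)c2cc1OCCCCC(=O)Nc1ccc(S(N)(=O)=O)cc1` gives 20000 nM. The steps are all small: a 1.7-fold higher number from compound 1 to compound 2 (0.23 log units; within the scatter), a 1.1-fold higher number from compound 1 to compound 3 (0.03 log units; within the scatter) and a 1.6-fold lower number from compound 2 to compound 3 (0.21 log units; within the scatter). On these numbers compound 3 stands with compound 1 and compound 2 in one band, every gap inside the scatter, so no ranking among the three is supported.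

Compound 4 `COc1cc2ncnc(Nc3ccccc3)c2cc1OCCCCC(=O)Nc1ccc(S(N)(=O)=O)cc1` is not yet measured. The change from compound 3 is phenyl in place of 3,4,5-trifluorophenyl on a nitrogen on an aromatic ring. Going by the values given here, the steps that bear on it are the two that also swap the ring on that nitrogen, from compound 1 to compound 3 and from compound 2 to compound 3, both within the scatter, and the third step from compound 1 to compound 2 is likewise within it. Nothing here shows that removing the three fluorines should move the number beyond the scatter in either direction. Compound 4 is therefore expected to stay in the same band, with the step of a 1.3-fold higher number from compound 3 to compound 4 (0.10 log units; within the scatter) estimated as flat. The estimate for compound 4 in this assay is 25000 nM, with a range from 10000 nM to 70000 nM.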

Compound 4, half-maximal inhibitory concentration: 14100 nM
For compound 4 the middle estimate is 1.8-fold (0.25 log units) above the measured one; measured number inside the range.
By their numbers in this assay, from the lowest: compounds 4, 1, 3 and 2 (each within the scatter of the next, the first and the last beyond it).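

In this assay, going by these compounds alone, the bare anilino ring gives the first step that lies beyond the scatter, a modest one: a 2.3-fold lower number from compound 2 to compound 4 (0.36 log units; beyond the scatter) marks hydrogen in place of methyl on an aromatic carbon as the one ring change so far that separates two compounds. The other two changes stay inside the scatter, with a 1.4-fold lower number from compound 3 to compound 4 (0.15 log units; within the scatter) for loss of the three fluorines and a 1.3-fold lower number from compound 1 to compound 4 (0.12 log units; within the scatter) for loss of the ethynyl, so compound 4, with no group on this ring, stands in one band with compound 1 and compound 3, and only compound 2 stands apart from it. Nothing measured bears on why the methyl step alone crosses the scatter.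

The compounds shown leave open whether an amine, a carboxylic acid or a methoxy on the anilino ring would carry the number out of this band in either direction. They also leave open whether a longer chain between the shared core and the sulfonamide-bearing amide would move it more than any ring change does here.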